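A few compounds are considered here, and "the series" means these few. Any claim that something is new, unique, unknown or untested is made for them only; others in the source may bear on it.

In a functional assay on DU-145 cells (Homo sapiens) for antiproliferative activity, read by fluorescence and propidium iodide staining, with a stated time of 96 h (on this read-out higher numbers stand for weaker inhibition and lower numbers for stronger inhibition), three compounds have been measured so far. Compound 1 (`O=C(Nc1ccc([N+](=O)[O-])c(C(F)(F)F)c1)c1ccc(Sc2ccc(O)cc2)cc1`) gives 5740 nM, compound 2 (`O=C(Nc1cccc(C(F)(F)F)c1)c1ccc(Sc2ccc(O)cc2)cc1`) gives 5950 nM, and compound 3 (`O=C(Nc1ccc([N+](=O)[O-])c(C(F)(F)F)c1)c1ccc(S(=O)(=O)c2ccc(O)cc2)cc1`) gives 8850 nM. The value of compound 3 lies within the scatter of both others, so the three cannot be ranked.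

Compound 4 (`O=C(Nc1cccc(C(F)(F)F)c1)c1ccc(S(=O)(=O)c2ccc(O)cc2)cc1`) differs from compound 3 by one change, hydrogen in place of nitro on an aromatic carbon. The same replacement has been measured once, as a 1.0-fold higher number from compound 1 to compound 2 (0.02 log units; within the scatter). That single pair carries the (4-hydroxyphenyl)sulfanyl group, whereas compound 3 carries the (4-hydroxyphenyl)sulfonyl group. The exchange of those two groups, seen as a 1.5-fold higher number from compound 1 to compound 3 (0.19 log units; within the scatter), also stays within the scatter, so nothing measured suggests that the replacement behaves differently here, although the data do not test this directly.

In this assay, the expected result is a 1.0-fold higher number from compound 3 to compound 4 (0.01 log units; within the scatter), with no change beyond the scatter. The estimate for compound 4 is 9000 nM, with an expected range of 5000 nM to 16000 nM.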

Compound 4, half-maximal inhibitory concentration: 17700 nM
The estimate for compound 4 lay 2.0-fold (0.29 log units) below the measured number; measured number outside the range, above it.
By their numbers in this assay, from the lowest: compounds 1, 2, 3 and 4 (each within the scatter of the next, the first and the last beyond it).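

At this position, ortho to a trifluoromethyl group and para to a large group, hydrogen in place of nitro has now been read on the sulfonyl-bearing core as well as the sulfanyl-bearing one: in this assay the replacement gives a 2.0-fold higher number from compound 3 to compound 4 (0.30 log units; within the scatter). The step on this second core therefore also stays within the scatter, and the nitro group is not shown to be needed on either core. The two readings of the change cannot be told apart: the same change on two cores in this assay, a 1.0-fold higher number (0.02 log units; within the scatter) from compound 1 to compound 2 and a 2.0-fold higher number (0.30 log units; within the scatter) from compound 3 to compound 4, 1.9-fold (0.29 log units) apart, within the scatter of two such steps.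

The compounds shown hold only nitro or hydrogen at this position, so it remains open whether an amine, a nitrile or a carboxylic acid there would move the number beyond the scatter. From the compounds shown here alone, all four compounds also carry the trifluoromethyl group, so what replacing it with a chlorine atom or a methyl group would do remains open too.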